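The compounds below may be only part of what the source reports. "The series", "measured", "known", "first", "only" and "open" are said of these compounds alone.

In an ADME assay on cells (Bone marrow cell, Rattus norvegicus) for cytotoxicity, with a stated time of 72 h (a lower number here means a stronger inhibitor, a higher number a weaker inhibitor), compound 1 (`O=C(N1CCC(c2ccccc2)CC1)N(c1nccc2ccccc12)[C@@H]1CCCNC1`) gives 12700 nM. Among the compounds with values here, this is the higher of the two numbers measured so far, and the gap lies beyond the usual scatter, since compound 2 (`O=C(CCc1ccc(-n2nnc3cccnc32)cc1)N(c1ncccc1Cl)[C@@H]1CCCNC1`) gives 3200 nM. The next compound to be tested is compound 3 (`Cn1ccc2ccnc(N(C(=O)N3CCC(c4ccccc4)CC3)[C@@H]3CCCNC3)c21`), which differs from compound 1 in one place, on an amide-type nitrogen whose other neighbours are a carbonyl carbon and a saturated ring carbon: a group of 10 heavy atoms (8 carbon, 2 nitrogen; one five-membered aromatic ring with 1 hetero atom, one six-membered aromatic ring with 1 hetero atom) in place of a group of 10 heavy atoms (9 carbon, 1 nitrogen; one six-membered aromatic ring of carbon only, one six-membered aromatic ring with 1 hetero atom), on an amide-type nitrogen. The isoquinolin-1-yl group leaves, and a group with a five-membered aromatic ring and a six-membered aromatic ring enters. Within the data shown here, no measured pair here differs in one place only, so the data offer no direct precedent for this change. In this assay, the expectation is therefore for no step beyond the scatter, and it stays anchored to compound 1 at 12700 nM. The expected value for compound 3 is 11000 nM, with an estimated range from 4500 nM to 27000 nM. This estimate corresponds to an expected step of a 1.2-fold lower number from compound 1 to compound 3 (0.06 log units; within the scatter).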

Compound 3, half-maximal inhibitory concentration in the Bone marrow cell assay: 11700 nM
For compound 3 the middle estimate is 1.1-fold (0.03 log units) below the measured one; the range from low to high includes it.
By their numbers in the Bone marrow cell assay, from the lowest: compound 2; then compounds 3 and 1 (each within the scatter of the next).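

Within the data shown here, exchanging the isoquinolin-1-yl group on the amide-type nitrogen for the group with a five-membered aromatic ring and a six-membered aromatic ring gives the first direct reading of a change at this position: in the Bone marrow cell assay compound 1 gives 12700 nM and compound 3 gives 11700 nM so the result is a 1.1-fold lower number from compound 1 to compound 3 (0.04 log units; within the scatter) and the two compounds cannot be told apart. In a physicochemical assay for lipophilicity, using the shake flask method (on this read-out higher numbers stand for higher lipophilicity and lower numbers for lower lipophilicity), compound 1 gives 1.4 and compound 3 gives 1.4 so the same exchange gives no change at the digits printed from compound 1 to compound 3 (within the scatter) and neither read-out separates the two compounds, even though the entering group has 2 hydrogen-bond acceptors where the group that leaves has 1. Nothing in the information available accounts for why these two groups read alike.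

The compounds shown leave open whether a group of another kind on this nitrogen, such as a single pyridine ring or an aromatic ring carrying an amine or a carboxylic acid, would produce a step beyond the scatter in either read-out. They also leave open whether the same exchange would read alike on a different core, such as that of compound 2.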